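This account rests on a few compounds, and the source may have more. Where it says the series, first, only, none or still open, it means among the compounds named here.

Compound 3 `CCCCCCCCc1cn(C(c2ccccc2)c2cc3cc(Br)ccc3nc2OC)nn1` was measured in an ADME assay on PANC-1 cells (Homo sapiens) for cytotoxicity, read by sulforhodamine B assay, with a stated time of 48 h, tested at 10 uM (on this read-out higher numbers stand for more inhibition at the one concentration tested (going by the name of the read-out) and lower numbers for less inhibition), and gave 12.1%, which stands second highest of the three numbers in hand. Its nearest neighbour is compound 1 `CCCCCCCc1cn(C(c2ccccc2)c2cc3cc(Br)ccc3nc2OC)nn1`, which in this assay gives 16.6%, while compound 2 `CCCCCCc1cn(C(c2ccccc2)c2cc3cc(Br)ccc3nc2OC)nn1` in this assay gives 6.08%. The step from compound 3 to compound 4 `CCCc1cn(C(c2ccccc2)c2cc3cc(Br)ccc3nc2OC)nn1` reads (hydrogen in place of pentyl on a saturated chain carbon, three bonds along the chain from an aromatic carbon). The measured steps that bear on it all change the chain length: a number 10.5 percentage points lower from compound 1 to compound 2 (beyond the scatter), a shortening by one carbon; a number 4.5 percentage points lower from compound 1 to compound 3 (within the scatter), a lengthening by one; and a number 6 percentage points higher from compound 2 to compound 3 (within the scatter). Only the shortening step reached beyond the scatter, and it lowered the number. Compound 4 carries a far shorter chain than any measured compound, so the expectation leans toward a lower number, though the two steps within the scatter leave the size uncertain. For compound 4 in this assay the estimated value is 6%, with a range from -2% to 15%. The step from compound 3 is therefore expected to be a number 6.1 percentage points lower from compound 3 to compound 4 (within the scatter).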

Compound 4, a percentage reported as inhibition, at one concentration (the size of the read-out at that concentration, not a potency): 11.3%
Compound 4: the middle estimate sits 5.3 percentage points below what was measured; low and high end bracket the measured number.
By their numbers in this assay, from the lowest: compounds 2, 4, 3 and 1 (each within the scatter of the next, the first and the last beyond it).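

In this assay, the cut from octyl to propyl gives a number 0.8 percentage points lower from compound 3 to compound 4 (within the scatter), so even this much larger shortening of the chain brings no change beyond the scatter. Compound 4 also stays within the scatter of the other two compounds, with a number 5.2 percentage points higher from compound 2 to compound 4 (within the scatter) and a number 5.3 percentage points lower from compound 1 to compound 4 (within the scatter). Among the compounds shown here, the single step beyond the scatter, a number 10.5 percentage points lower from compound 1 to compound 2 (beyond the scatter), therefore does not grow into a steady fall as the chain shortens, and compound 4 goes against any such pattern.

No supporting data are available to explain this result. From the compounds shown here alone, it remains open whether a chain longer than octyl, or an amine or a carboxylic acid at the end of the chain, would move the number beyond the scatter.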